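The source may report more compounds than this note shows. Statements on the series, on what has been measured and on what is new or still open speak of the compounds shown alone.

Of the compounds shown here, three built on one shared core have been tested in a functional assay on BJAB cells (Homo sapiens) for antiproliferative activity, with a stated time of 4 days; a higher number here means that more compound is needed for the effect, a lower number that less compound is needed. Compound 1 `Cc1nn(-c2nc(-c3ccc(Cl)c(Cl)c3)c(SC(C)C)s2)c(C(=O)O)c1-c1cc(C#N)cc(C(F)(F)F)c1` gives 3600 nM and stands second highest of the three numbers. Its nearest neighbour is compound 3 `Cc1nn(-c2nc(-c3ccc(Cl)c(Cl)c3)c(SC(C)C)s2)c(C(=O)O)c1-c1cc(C(F)(F)F)cc(C(F)(F)F)c1`, which gives 1800 nM; the step of a 2.0-fold lower number from compound 1 to compound 3 (0.30 log units; within the scatter) stays within the scatter, so the two compounds cannot be ranked against each other. The furthest is compound 2 `COC(=O)c1c(Cc2ccccc2[N+](=O)[O-])c(C)nn1-c1nc(-c2ccc(Cl)c(Cl)c2)c(SC(C)C)s1`, which gives 93000 nM, a number far beyond the scatter from compound 1. Compound 2 differs from compound 1 in several places at once, so its value alone does not show what any single change does.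

Compound 4 `Cc1nn(-c2nc(-c3ccc(Cl)c(Cl)c3)c(SC(C)C)s2)c(C(=O)O)c1-c1cncc(C#N)c1` has not yet been measured. It differs from compound 1 in one place: 5-cyanopyridin-3-yl in place of 3-cyano-5-(trifluoromethyl)phenyl on an aromatic carbon

For the measured compounds named here, the only measured step touching this part of the shared core is a 2.0-fold lower number from compound 1 to compound 3 (0.30 log units; within the scatter), and it did not leave the scatter. Going by the values given here, no measured step exchanges the phenyl ring for a pyridinyl ring, so the expectation rests on that single step and the general pattern that changes on this ring have so far moved the number little. A modest step is therefore expected, with the larger chance that it runs toward a higher number.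

Compound 4 is expected to give about 6000 nM, within a range from 2000 nM to 20000 nM. This estimate corresponds to an expected step of a 1.7-fold higher number from compound 1 to compound 4 (0.22 log units; within the scatter).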

Compound 4, half-maximal effective concentration: 20000 nM
Compound 4: the middle estimate sits 3.3-fold (0.52 log units) below what was measured; measured number inside the range.
By their numbers in this assay, from the lowest: compounds 3 and 1 (each within the scatter of the next); then compound 4; then compound 2.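

In this assay, putting 5-cyanopyridin-3-yl in place of 3-cyano-5-(trifluoromethyl)phenyl gives a 5.6-fold higher number from compound 1 to compound 4 (0.74 log units; beyond the scatter). This shows that the number does respond to what this position carries, which the earlier step (a 2.0-fold lower number from compound 1 to compound 3 (0.30 log units; within the scatter)) could not show, as it stayed within the scatter. The change alters two things at once, since the trifluoromethyl group is lost and a ring carbon gives way to a ring nitrogen while the nitrile stays, and no measurement at hand separates these two parts or offers a cause for the higher number.

The compounds shown leave open whether a phenyl ring carrying only the nitrile, or a pyridinyl ring that keeps the trifluoromethyl group, would fall closer to compound 1 or to compound 4, and either result would help divide the step between the two parts of the change. They also leave open how the number would respond to a different kind of group on this ring, such as an amine or a methoxy group.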